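The source may report more compounds than this note shows. Statements on the series, on what has been measured and on what is new or still open speak of the compounds shown alone.

Working notes on the series

Compound 1 `COc1ccc(/C=C2\CN(Cc3cn(Cc4cccc(Cl)c4)nn3)C/C(=C\c3ccc(OC)cc3)C2=O)cc1` is the parent of one pair. In a functional assay on DU-145 cells (Homo sapiens) for cytotoxicity, read by MTT assay, with a stated time of 24 h (on this read-out lower numbers stand for stronger inhibition and higher numbers for weaker inhibition), compound 1 gives 15400 nM. Compound 3 `COc1ccc(/C=C2\CN(Cc3cn(Cc4ccccc4Cl)nn3)C/C(=C\c3ccc(OC)cc3)C2=O)cc1` carries 2-chlorophenyl in place of 3-chlorophenyl on a saturated chain carbon bound to an aromatic nitrogen; in this assay compound 3 gives 17800 nM. Among the measured compounds shown here, the step of a 1.2-fold higher number from compound 1 to compound 3 (0.06 log units; within the scatter) is the only measured instance of this change, and it sits within the scatter, so the two values are read as equivalent.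

Compound 2 `COc1ccc(/C=C2\CN(C(=S)SCc3cn(Cc4cccc(Cl)c4)nn3)C/C(=C\c3ccc(OC)cc3)C2=O)cc1` has a different core; the difference between the core of compound 2 and the core of compound 1 is not broken down here. In this assay compound 2 reaches only a limit of the assay, > 80000 nM, and no number is available for it. The limit is the limit of > 80000 nM in this assay, at which 1 of the 3 values shown sits.

Compound 4 `COc1ccc(/C=C2\CN(C(=S)SCc3cn(Cc4ccccc4Cl)nn3)C/C(=C\c3ccc(OC)cc3)C2=O)cc1` is the not yet measured member. It carries 2-chlorophenyl in place of 3-chlorophenyl on a saturated chain carbon bound to an aromatic nitrogen, the same change that takes compound 1 to compound 3, made on the core of compound 2.

Expectation for compound 4 in this assay rests on two points. The first is the measured step of a 1.2-fold higher number from compound 1 to compound 3 (0.06 log units; within the scatter), which shows the change leaving the number essentially where it was. The second is that compound 2 sits at the limit > 80000 nM, so the starting point itself is only a bound. The step from compound 2 to compound 4 is therefore expected to be small, about a step that the limit leaves unreadable from compound 2 to compound 4, and the most likely outcome is that compound 4 is also reported only as a limit. The estimate for compound 4 is 100000 nM, with a range from 40000 nM to 250000 nM.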

Compound 4, half-maximal inhibitory concentration: > 80000 nM
Compound 4 was reported as a limit; the forecaster's own chance of this, stated with the estimate: 75%; the middle value does not contradict the limit.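

Among the compounds shown here, compound 2 and compound 4 are both reported only as limits in this assay, so no step from compound 2 to compound 4 can be read: the limit of > 80000 nM in this assay, at which 2 of the 4 values shown sit. The compounds shown leave open whether 2-chlorobenzyl in place of 3-chlorobenzyl changes the number on the core of compound 2, and how far either compound lies beyond its limit.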